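This account rests on a few compounds, and the source may have more. Where it says the series, first, only, none or still open, it means among the compounds named here.

Of the compounds shown here, two have been measured so far. Compound 1 `CC(=O)c1ccc(NC(=O)C(C(C)C)N(C(=O)c2ccccc2)S(=O)(=O)c2ccc(C)cc2)cc1` was tested in a functional assay for inhibition, read by spectrophotometry, with a stated time of 20 min, tested at 1 mg/mL (on this read-out lower numbers stand for a weaker effect and higher numbers for a stronger effect at the one concentration tested), and gave 15.6%. Compound 2 `CC(=O)c1ccc(NC(=O)C2CCCN2S(=O)(=O)c2ccc([N+](=O)[O-])cc2)cc1`, tested in this assay, gave 22.7%. On the numbers shown, compound 2 stands together with compound 1: the gap between them falls within the usual scatter of repeated measurements, so nothing separates the two in this assay.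

Compound 3 `CC(=O)c1ccc(NC(=O)C2CCCN2S(=O)(=O)c2ccccc2)cc1` has not yet been measured. It differs from compound 2 in one place only: hydrogen in place of nitro on an aromatic carbon.

Going by the values given here, no step between measured compounds is available to guide the expectation, since compound 1 and compound 2 differ in several places at once. Without such a step, the expectation for compound 3 rests on compound 2 alone. In this assay compound 3 is expected to give 19%, with a range from 7% to 31%. The expected step of a number 3.7 percentage points lower from compound 2 to compound 3 (within the scatter) is small, and may well lie within the scatter rather than beyond it.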

Compound 3, a percentage reported as inhibition, at one concentration (the size of the read-out at that concentration, not a potency): 22.8%
Compound 3: middle estimate off by 3.8 percentage points, on the low side; low and high end bracket the measured number.
By their numbers in this assay, from the lowest: compounds 1, 2 and 3 (each within the scatter of the next).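

In this assay, hydrogen in place of nitro on the aromatic ring, the change from 4-nitrophenyl to phenyl, gives a number 0.1 percentage points higher from compound 2 to compound 3 (within the scatter) and so leaves no difference that can be told apart from the scatter. Going by these compounds alone, this is the first comparison in which only one place changes, and it shows that, on this core, the nitro group with its 3 heavy atoms and 2 hydrogen-bond acceptors can leave this position without a detectable change in the read-out at the one concentration tested. No measurement at hand speaks to why compound 2 and compound 3 read alike.

Going by these compounds, what remains open is whether any other group at this same place, such as an amine, a methoxy group or a carboxylic acid, would move the number beyond the scatter, or whether this position tolerates a wide range of groups. A single concentration also gives the size of the effect rather than a potency, so compound 2 and compound 3 could still differ at other concentrations.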